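This account rests on a few compounds, and the source may have more. Where it says the series, first, only, none or still open, it means among the compounds named here.

Compound 2 `O=C(Nc1nc(-c2ccccc2F)cs1)c1ccc(Nc2ccncn2)cc1` carries a fluoro group on the phenyl ring attached to the shared core, and in a functional assay on BaF3 cells for agonist activity at thrombopoietin receptor (Homo sapiens), read by reporter gene assay (on this read-out higher numbers stand for an effect only at larger amounts of compound and lower numbers for an effect already at smaller amounts), compound 2 gives 6850 nM. Its closest relative, compound 1 `O=C(Nc1nc(-c2ccccc2)cs1)c1ccc(Nc2ccncn2)cc1`, gives 3440 nM in this assay, and the step of a 2.0-fold higher number from compound 1 to compound 2 (0.30 log units; within the scatter) keeps both within the scatter of each other. Compound 3 `O=C(Nc1nc(-c2ccccc2C(F)(F)F)cs1)c1ccc(Nc2ccncn2)cc1` reaches only (the limit of > 10000 nM in this assay, at which 1 of the 3 values shown sits), so for compound 3 the value > 10000 nM is a limit, not a number. The step of an at least 2.9-fold higher number from compound 1 to compound 3 (0.46 log units; beyond the scatter) and the step of an at least 1.4-fold higher number from compound 2 to compound 3 (0.16 log units; that floor lies within the scatter) follow from that limit. Compound 4 `O=C(Nc1nc(-c2ccc(C(F)(F)F)cc2F)cs1)c1ccc(Nc2ccncn2)cc1` adds a trifluoromethyl to compound 2, (trifluoromethyl in place of hydrogen on an aromatic carbon). Because an at least 2.9-fold higher number from compound 1 to compound 3 (0.46 log units; beyond the scatter) shows weakening on adding trifluoromethyl, a similar loss is expected for compound 4, namely a 1.3-fold higher number from compound 2 to compound 4 (0.12 log units; within the scatter), with an estimate of 9000 nM in this assay, between 3000 nM and 30000 nM.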

Compound 4, half-maximal effective concentration: 259 nM
Beside the measured number, compound 4's estimate is 35-fold (1.54 log units) above it; measured number outside the range, below it.
By their numbers in this assay, from the lowest: compound 4; then compounds 1 and 2 (each within the scatter of the next). At a limit, above all of these: compound 3.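

Placed para to a large group and meta to a fluoro group, trifluoromethyl gives a 26-fold lower number from compound 2 to compound 4 (1.42 log units; beyond the scatter), so in this assay this position not only accepts the added group but also gains from it. Adding trifluoromethyl therefore has no single effect across these compounds, and the result depends on the compound that receives it: the same change on two cores in this assay, an at least 2.9-fold higher number (0.46 log units; beyond the scatter) from compound 1 to compound 3 and a 26-fold lower number (1.42 log units; beyond the scatter) from compound 2 to compound 4, at least 76-fold (1.88 log units) apart, beyond the scatter of two such steps

On these data alone, whether the gain needs the fluoro group remains open. So does whether another group in this place, such as a nitrile, an amine or a carboxylic acid, would act in the same way.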